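A few compounds are considered here, and "the series" means these few. Any claim that something is new, unique, unknown or untested is made for them only; others in the source may bear on it.

Measured so far:
compound 1 `Cc1ccc(C)c(Oc2ccc(CC3SC(=O)NC3=O)cc2)c1` – 238 nM in a functional assay for agonist activity at Free fatty acid receptor 1 (Homo sapiens), read by FLIPR, in the presence of a further agent that is not named here; on this read-out higher numbers stand for an effect only at larger amounts of compound and lower numbers for an effect already at smaller amounts
compound 2 `Cc1ccc(Oc2ccc(CC3SC(=O)NC3=O)cc2)nc1` – 4470 nM in this assay

Of these two numbers, compound 2 holds the higher one, and its distance to compound 1 lies well beyond the usual scatter, so compound 2 is the weaker of the pair on this read-out. Compound 3 `Cc1cccc(Oc2ccc(CC3SC(=O)NC3=O)cc2)c1` is not yet measured. It differs from compound 2 in one place: 3-methylphenyl in place of 5-methylpyridin-2-yl on an oxygen on an aromatic ring. The ring that enters is of the same kind as the ring carried by compound 1, which gives 238 nM in this assay, although compound 1 bears a second methyl that compound 3 lacks. On that basis a step downward, toward smaller amounts, is expected, with the size described by a 6.4-fold lower number from compound 2 to compound 3 (0.81 log units; beyond the scatter), though not necessarily reaching compound 1. For compound 3 the value in this assay is estimated at 700 nM, within a range from 200 nM to 2500 nM.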

Compound 3, half-maximal effective concentration: 203 nM
The estimate for compound 3 lay 3.4-fold (0.54 log units) above the measured number; the measured number falls inside the stated range.
By their numbers in this assay, from the lowest: compounds 3 and 1 (each within the scatter of the next); then compound 2.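

Exchanging 5-methylpyridin-2-yl for 3-methylphenyl on the oxygen keeps the count of heavy atoms yet gives a 22-fold lower number from compound 2 to compound 3 (1.34 log units; beyond the scatter) in this assay, so this position responds strongly to the identity of the ring, although the step covers the whole group and cannot be assigned to the ring nitrogen alone. Hydrogen in place of the second methyl gives a 1.2-fold lower number from compound 1 to compound 3 (0.07 log units; within the scatter), so on this read-out that methyl can be removed without a readable difference. Nothing at hand explains either result.

The compounds shown do not tell whether the remaining methyl matters, since an unsubstituted phenyl is not among them, or how a chlorine or a methoxy group would behave in its place. They also leave the contribution of the ring nitrogen unseparated from that of the methyl's placement.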